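Removing the ethyl group from compound 1

The compounds below may be only part of what the source reports. "The series", "measured", "known", "first", "only" and "open" are said of these compounds alone.

Measured in an ADME assay on the whole organism (plasma, strain Sprague-Dawley) for pharmacokinetics, with Rattus norvegicus as the target, read by LC-MS, at a dose of 10 mg/kg by the oral route (on this read-out lower numbers stand for lower exposure and higher numbers for higher exposure at the dose given), so far:
Compound 1 `CCN1CCC(Oc2ccnc(C(=O)Nc3ccc(NC(=O)Nc4cc(C(C)(C)C)on4)cc3)c2)CC1` gives "not determined" (no result reported)
Compound 2 `CC1(C)CC(Oc2ccc(C(=O)Nc3ccc(NC(=O)Nc4cc(C(C)(C)C)on4)cc3)nc2)CC(C)(C)N1` gives 1280 ng.h/mL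
Compound 3 `CCN1CCC(Cc2ccc(C(=O)Nc3ccc(NC(=O)Nc4cc(C(C)(C)C)on4)cc3)nc2)CC1` gives 707 ng.h/mL

Compound 1 has no number in this assay and so offers no starting value for what follows. Compound 4 `CC(C)(C)c1cc(NC(=O)Nc2ccc(NC(=O)c3cc(OC4CCNCC4)ccn3)cc2)no1` has not yet been measured. It departs from compound 1 by a single change, (hydrogen in place of ethyl on an amine nitrogen in a ring), which puts hydrogen in place of ethyl on an amine nitrogen in a ring.

Within the data shown here, only one measured step is available, a 1.8-fold lower number from compound 2 to compound 3 (0.26 log units; within the scatter), and it bears on this change only loosely. It exchanges the whole (2,2,6,6-tetramethylpiperidin-4-yl)oxy group for (1-ethylpiperidin-4-yl)methyl, so it does not isolate the loss of ethyl. No step of a definite size or direction can therefore be expected from compound 1 to compound 4, and the data give no reason to expect compound 4 to lie far from the two measured compounds. The best available guide is the level set by compound 2 at 1280 ng.h/mL and by compound 3 at 707 ng.h/mL, with a wide margin for the untested change.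

For compound 4 the expected value is 900 ng.h/mL and the estimated range runs from 250 ng.h/mL to 3000 ng.h/mL at this stage.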

Compound 4, area under the concentration-time curve: 191 ng.h/mL
Compound 4: the middle estimate sits 4.7-fold (0.67 log units) above what was measured; measured number outside the range, below it.
By their numbers in this assay, from the lowest: compound 4; then compounds 3 and 2 (each within the scatter of the next).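

No step can be read from compound 1 to compound 4 in this assay, as compound 1 has no number there to compare. The compounds shown leave open what hydrogen in place of ethyl on the ring amine nitrogen does to exposure in this assay. No evidence at hand bears on the result for compound 4.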